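The source may report more compounds than this note shows. Statements on the series, on what has been measured and on what is new or still open speak of the compounds shown alone.

In a functional assay on K562 cells (Homo sapiens) for cytotoxicity, read by MTT assay, with a stated time of 72 h (a higher number here means a weaker inhibitor, a lower number a stronger inhibitor), the series on the shared core is flat so far: compound 1 `C=C1C(=O)[C@@]23C(=O)OC[C@]4(C(=O)CCC(C)(C)[C@H]4C=O)[C@@H]2CC[C@@H]1[C@H]3OC(C)=O` gives 1390 nM, compound 2 `C=C1C(=O)[C@@]23C(=O)OC[C@]4(C(=O)CCC(C)(C)[C@H]4C=O)[C@@H]2CC[C@@H]1[C@H]3OC(=O)CC` gives 1310 nM and compound 3 `C=C1C(=O)[C@@]23C(=O)OC[C@]4(C(=O)CCC(C)(C)[C@H]4C=O)[C@@H]2CC[C@@H]1[C@H]3OC(=O)c1ccccc1` gives 1480 nM. Compound 3 therefore stands level with the other two, within the scatter of both. Compound 4 `C=C1C(=O)[C@@]23C(=O)OC[C@]4(C(=O)CCC(C)(C)[C@H]4C=O)[C@@H]2CC[C@@H]1[C@H]3OC(=O)c1ccc(C)cc1` makes one change to compound 3: methyl in place of hydrogen on an aromatic carbon. The nearest evidence is a 1.1-fold higher number from compound 1 to compound 3 (0.03 log units; within the scatter) and a 1.1-fold higher number from compound 2 to compound 3 (0.05 log units; within the scatter), alongside a 1.1-fold lower number from compound 1 to compound 2 (0.03 log units; within the scatter), all within the scatter. None of these steps tests a substituent on the aromatic ring, so nothing beyond the scatter is expected in this assay. The expected step is a 1.1-fold lower number from compound 3 to compound 4 (0.02 log units; within the scatter). For compound 4 the estimated value is 1400 nM, with an expected range of 850 nM to 2300 nM.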

Compound 4, half-maximal inhibitory concentration: 1270 nM
Compound 4: middle estimate off by 1.1-fold (0.04 log units), on the high side; the measured number falls inside the stated range.
By their numbers in this assay, from the lowest: compounds 4, 2, 1 and 3 (each within the scatter of the next).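

In this assay, within the data shown here, methyl on the aromatic carbon para to a large group is the first ring substituent, and it stays within the scatter (a 1.2-fold lower number from compound 3 to compound 4 (0.07 log units; within the scatter)). The 4-methylphenyl group on the carbonyl carbon also stays level with ethyl (a 1.0-fold lower number from compound 2 to compound 4 (0.01 log units; within the scatter)) and methyl (a 1.1-fold lower number from compound 1 to compound 4 (0.04 log units; within the scatter)). No supporting evidence bears on this flat result.

On these data alone, whether an amine or a carboxylic acid on the ring would move the number remains open. So does the effect of a longer chain on the carbonyl carbon.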